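Compound 2 and a benzothiazolyl swap

The source may hold more compounds than are shown below. What is called first, only, known or untested is meant among the compounds shown, and "the series" means these compounds.

Values from a physicochemical assay for solubility, read by spectrophotometry, in phosphate buffer, measured as kinetic solubility, with a stated time of 18 h, at pH 7.4 (on this read-out lower numbers stand for lower solubility and higher numbers for higher solubility), are as follows.
Compound 1 `O=C(Nc1nc2c(Cl)cccc2s1)c1cc([N+](=O)[O-])ccc1Cl` gives 720 nM
Compound 2 `Cc1cc(NC(=O)c2cc([N+](=O)[O-])ccc2Cl)cc(-c2nc3ccccc3o2)c1O` gives 90 nM
Compound 3 `O=C(Nc1nc2ccc(F)cc2s1)c1cc([N+](=O)[O-])ccc1Cl` gives 570 nM

Compound 2 (90 nM) holds the lowest of the three numbers. Compound 3 and compound 1 both stand higher, and each gap lies beyond the scatter. Compound 4 `Cc1cc(NC(=O)c2cc([N+](=O)[O-])ccc2Cl)cc(-c2nc3ccccc3s2)c1O` has not yet been measured. The change from compound 2 (1,3-benzothiazol-2-yl in place of 1,3-benzoxazol-2-yl on an aromatic carbon) puts 1,3-benzothiazol-2-yl in place of 1,3-benzoxazol-2-yl on an aromatic carbon, ortho to a hydroxy group and meta to a methyl group. Among the measured compounds shown here, no measured pair in this set shows that exchange. The expectation therefore rests on compound 2 (90 nM) alone, and it carries wide uncertainty. In this assay the expected step (a 1.3-fold lower number from compound 2 to compound 4 (0.11 log units; within the scatter)) is no larger than the scatter, with a slight lean towards the lower side. Compound 4 is expected to read 70 nM within an estimated range of 25 nM to 220 nM when the measurement is made.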

Compound 4, solubility: 430 nM
Compound 4: the middle estimate sits 6.1-fold (0.79 log units) below what was measured; measured number above the stated range.
By their numbers in this assay, from the lowest: compound 2; then compounds 4, 3 and 1 (each within the scatter of the next).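

In this assay, among the compounds shown here, the exchange of 1,3-benzoxazol-2-yl for 1,3-benzothiazol-2-yl on an aromatic carbon, ortho to a hydroxy group and meta to a methyl group, gives a 4.8-fold higher number from compound 2 to compound 4 (0.68 log units; beyond the scatter), the first direct reading of this change in the set. The read-out at this position therefore responds to the exchange, although the two groups match in heavy-atom count, ring types and hydrogen-bond donors and acceptors, and differ only in carrying oxygen or sulfur. No measured property is available to explain the step.

On these data alone, the change rests on this single pair, so it remains open whether the step would hold with a methoxy group or an amine in place of the hydroxy group. Also open, as far as these compounds go, is how an amine or a carboxylic acid on the entering group would read.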